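The source may report more compounds than this note shows. Statements on the series, on what has been measured and on what is new or still open speak of the compounds shown alone.

Measured in a functional assay on HeLa cells (Homo sapiens) for inhibition, read by MTT assay, with a stated time of 48 h; on this read-out lower numbers stand for stronger inhibition and higher numbers for weaker inhibition:
- compound 1 `Brc1ccc2[nH]cc(C(c3ccccc3)c3c[nH]c4ccc(Br)cc34)c2c1`: 900 nM
- compound 2 `COc1ccc(C(c2c[nH]c3ccc(Br)cc23)c2c[nH]c3ccc(Br)cc23)cc1OC`: 6100 nM
- compound 3 `Brc1ccc2[nH]cc(C(c3ccc4ccccc4c3)c3c[nH]c4ccc(Br)cc34)c2c1`: 4300 nM

All three share a core and differ only in the group on a saturated chain carbon bound to two aromatic carbons. Compound 3 sits in the upper pair of these numbers. Its gap to the closest value is small, with a 1.4-fold lower number from compound 2 to compound 3 (0.15 log units; within the scatter). Its gap to the lowest value is larger, with a 4.8-fold higher number from compound 1 to compound 3 (0.68 log units; beyond the scatter).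

The compound still to be tested is compound 4 `Clc1ccc(C(c2c[nH]c3ccc(Br)cc23)c2c[nH]c3ccc(Br)cc23)cc1`, which has 4-chlorophenyl in place of naphthalen-2-yl at that carbon: 4-chlorophenyl in place of naphthalen-2-yl on a saturated chain carbon bound to two aromatic carbons.

Among the compounds with values here, two measured steps bear on this change. Replacing phenyl with naphthalen-2-yl gave a 4.8-fold higher number from compound 1 to compound 3 (0.68 log units; beyond the scatter), and replacing phenyl with 3,4-dimethoxyphenyl gave a 6.8-fold higher number from compound 1 to compound 2 (0.83 log units; beyond the scatter). Within the data shown here, both moved the number up, so plain phenyl holds the lowest value so far. Compound 4 is closer to compound 1 in having a phenyl ring, but compound 2 also has one and still shows a high number. Among the measured compounds shown here, no chlorinated compound has been measured, so only part of the gap to compound 1 is expected to be recovered in this assay.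

The expected change is small and downward, at a 1.8-fold lower number from compound 3 to compound 4 (0.25 log units; within the scatter). Compound 4 is estimated at 2400 nM, within a range of 800 nM to 6500 nM.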

Compound 4, half-maximal inhibitory concentration: 4800 nM
Compound 4: middle estimate off by 2.0-fold (0.30 log units), on the low side; the range from low to high includes it.
By their numbers in this assay, from the lowest: compound 1; then compounds 3, 4 and 2 (each within the scatter of the next).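

In this assay, one chloro in place of hydrogen on the phenyl ring is enough to shift the result, with a 5.3-fold higher number from compound 1 to compound 4 (0.73 log units; beyond the scatter) and thus a clear separation from the unsubstituted compound. The new compound cannot be told apart from the other two replacements, with a 1.1-fold higher number from compound 3 to compound 4 (0.05 log units; within the scatter) and a 1.3-fold lower number from compound 2 to compound 4 (0.10 log units; within the scatter), so exchanging naphthalen-2-yl, with 10 heavy atoms, for 4-chlorophenyl, with 7, makes no readable difference. At this position, on a saturated chain carbon bound to two aromatic carbons, plain phenyl therefore stands alone at the low end of the four numbers, while all three replacements of it form one group, and no compound shown goes against this.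

Going by these compounds, it remains open whether only plain phenyl gives the low number, or whether a methyl group at this carbon, or a phenyl ring carrying fluoro, an amine or a carboxylic acid, would give a similar one. Nothing measured here explains why these three groups fall together or why plain phenyl stands apart.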